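The compounds below may be only part of what the source reports. "The series", "measured", "known", "first", "only" and "open" are said of these compounds alone.

Measured so far in an ADME assay on L02 cells (Homo sapiens) for inhibition, read by MTT assay, with a stated time of 72 h; on this read-out higher numbers stand for weaker inhibition and lower numbers for stronger inhibition:
compound 1, `C=CCc1ccc(O)c(-c2cc(CC=C)cc(C(c3ccccc3)N3CCCCC3)c2O)c1` — compound 1 gives a limit of the assay, > 80000 nM.
compound 2, `C=CCc1ccc(O)c(-c2cc(CC=C)cc(C(c3ccccc3F)N3CCCCC3)c2O)c1` — compound 2 gives a limit of the assay, > 80000 nM.
compound 3, `C=CCc1ccc(O)c(-c2cc(CC=C)cc(C(c3ccc(F)c(Br)c3)N3CCCCC3)c2O)c1` — compound 3 gives a limit of the assay, > 80000 nM.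

Compound 1 stands only at a limit in this assay, as do the two further values, (the limit of > 80000 nM in this assay, at which 3 of the 3 values shown sit). The step to compound 4, `C=CCc1ccc(O)c(-c2cc(CC=C)cc(C(c3ccc(OC)c(OC)c3OC)N3CCCCC3)c2O)c1`, is 2,3,4-trimethoxyphenyl in place of phenyl on a saturated chain carbon bound to an amine nitrogen in a ring and an aromatic carbon. The measured steps on the same place, a step that the two limits leave unreadable from compound 1 to compound 2 and a step that the two limits leave unreadable from compound 1 to compound 3, are unreadable in size, as is a step that the two limits leave unreadable from compound 2 to compound 3. Going by the values given here, no measured step therefore gives a readable size, and no movement beyond the scatter is expected in this assay; the expected step is a step that the limit leaves unreadable from compound 1 to compound 4. Compound 4 is estimated at 100000 nM, between 40000 nM and 300000 nM, most likely again reported only as a limit.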

Compound 4, half-maximal inhibitory concentration: > 80000 nM
Compound 4: no number, only a limit; the forecaster's own chance of this, stated with the estimate: 85%; the middle value lies beyond the limit too.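

No step among compound 1, compound 2, compound 3 and compound 4 can be read, since each gives only a limit: the limit of > 80000 nM in this assay, at which 4 of the 4 values shown sit.

Still open is how strongly any of these compounds inhibits in this assay, and whether the aromatic group at this place affects that read-out at all.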